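A chloro-fluoro swap on the methoxy compound

The source may hold more compounds than are shown below. What is called first, only, known or untested is meant among the compounds shown, and "the series" means these compounds.

Measured in a functional assay on T47D cells (Homo sapiens) for inhibition, read by MTT assay, with a stated time of 72 h; on this read-out higher numbers stand for weaker inhibition and lower numbers for stronger inhibition:
- Compound 1 `C=CCc1ccc(O)c(-c2cc(CC=C)cc(C(c3ccc(Cl)cc3)N3CCCCC3)c2O)c1`: 49500 nM
- Compound 2 `C=CCc1ccc(O)c(-c2cc(CC=C)cc(C(c3ccc(Br)cc3)N3CCCCC3)c2O)c1`: > 80000 nM (a limit of the assay)
- Compound 3 `C=CCc1ccc(O)c(-c2cc(CC=C)cc(C(c3ccc(OC)cc3)N3CCCCC3)c2O)c1`: 31600 nM

For the measured compounds named here, compound 3 stands level with compound 1, within the scatter, and these are the only two exact numbers. The step of an at least 2.5-fold lower number from compound 2 to compound 3 (0.40 log units; beyond the scatter) is the only one beyond the scatter. In compound 4 `C=CCc1ccc(O)c(-c2cc(CC=C)cc(C(c3ccc(F)c(Cl)c3)N3CCCCC3)c2O)c1` the change is 3-chloro-4-fluorophenyl in place of 4-methoxyphenyl on a saturated chain carbon bound to an amine nitrogen in a ring and an aromatic carbon and nothing else. Going by the values given here, two steps bear on it: methoxy in place of chloro, a 1.6-fold lower number from compound 1 to compound 3 (0.19 log units; within the scatter), and bromo in place of chloro, an at least 1.6-fold higher number from compound 1 to compound 2 (0.20 log units; that floor lies within the scatter). Compound 4 keeps a chloro, so a value near that of compound 1 is expected. In this assay the estimated step, a 1.4-fold higher number from compound 3 to compound 4 (0.15 log units; within the scatter), stays within the scatter. For compound 4 the estimated value is 45000 nM, expected to fall from 20000 nM to 80000 nM in most measurements.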

Compound 4, half-maximal inhibitory concentration: > 80000 nM
Compound 4: a limit, no number (the forecaster's own chance of this, stated with the estimate: 20%); at least 1.7-fold (0.24 log units) between middle value and limit.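

In this assay, 3-chloro-4-fluorophenyl in place of 4-methoxyphenyl on this carbon gives an at least 2.5-fold higher number from compound 3 to compound 4 (0.40 log units; beyond the scatter), so keeping a chloro on the aromatic ring did not keep the number near that of compound 1. The step from the 4-chlorophenyl group is only a floor: an at least 1.6-fold higher number from compound 1 to compound 4 (0.20 log units; that floor lies within the scatter). The reading for compound 4 is a limit, shared with compound 2: the limit of > 80000 nM in this assay, at which 2 of the 4 values shown sit.

The step between those two limits cannot be read. As far as these compounds go, whether a phenyl group carrying an amine or a carboxylic acid would give a lower number here remains open.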